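The source may report more compounds than this note shows. Statements on the series, on what has been measured and on what is new or still open speak of the compounds shown alone.

Working notes on the series. In an assay on brain for displacement of a labelled ligand from Sigma non-opioid intracellular receptor 1 (Cavia porcellus) (on this read-out lower numbers stand for stronger inhibition and higher numbers for weaker inhibition), compound 1 `NCC[C@H]1CCO[C@@H](c2ccccc2)O1` gives only a limit, > 10000 nM. Compound 2 `NCC[C@@H]1CCO[C@H](c2ccccc2)O1` also gives only a limit in this assay, > 10000 nM. The step that the two limits leave unreadable from compound 1 to compound 2 is therefore unreadable, which rests on the limit of > 10000 nM in this assay, at which 2 of the 2 values shown sit, together with the fact that compounds 1 and 2 differ only in the configuration as drawn. Compound 3 `NCCC1CCOC(c2ccccc2)O1` differs from compound 2 by the two compounds have the same atoms and bonds; at least one stereo element is drawn with a configuration in one of them and without one in the other: 2 of 2 stereo elements differ; a stereocentre at a saturated ring carbon is drawn R in compound 2 and without a configuration in compound 3; a stereocentre at a saturated ring carbon is drawn S in compound 2 and without a configuration in compound 3. Since both configured forms sit at the limit, no step beyond the scatter is expected for compound 3, which is estimated at 20000 nM with a range of 10000 nM to 60000 nM, most likely reported again as a limit. The expected step from compound 2 is a step that the limit leaves unreadable from compound 2 to compound 3.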

Compound 3, inhibition constant: > 10000 nM
Compound 3 was reported as a limit; the forecaster's own chance of this, stated with the estimate: 90%; the middle value does not contradict the limit.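

In this assay compound 3 gives > 10000 nM as a limit of the assay. The steps among compound 1, compound 2 and compound 3 therefore cannot be read. The compounds shown leave open whether configuration at the two stereocentres affects this read-out at all.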